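This account rests on a few compounds, and the source may have more. Where it says the series, first, only, none or still open, it means among the compounds named here.

Measured so far:
compound 1 `CN(C)/C(=N/CCCCn1nc(-c2ccccc2)ccc1=O)NC#N` gives 80.7%
compound 2 `C#CCN/C(=N/CCCCn1nc(-c2ccccc2)ccc1=O)NC#N` gives -12.9%
compound 3 `CCC/N=C(/NC#N)NCCCn1nc(C)ccc1=O` gives 17.5%

In a functional assay on the whole organism with Rattus norvegicus as the target, at a dose of 100 mg/kg (a lower number here means less inhibition, a higher number more inhibition at the dose given (going by the name of the read-out)), compound 1 stands highest of the three; compound 3 is nearest and compound 2 furthest, both beyond the scatter. Compound 4 `C/N=C(\S)NCCCCCCn1nc(-c2ccccc2)ccc1=O` has not been measured. It differs from compound 1 by a group of 7 heavy atoms (4 carbon, 2 nitrogen, 1 sulfur; no ring) in place of a group of 8 heavy atoms (4 carbon, 4 nitrogen; no ring), on a saturated chain carbon, four bonds along the chain from an aromatic nitrogen. For the measured compounds named here, only one measured step bears on this: a number 93.6 percentage points lower from compound 1 to compound 2 (beyond the scatter), which also alters the group on that saturated chain carbon, and it was a large drop. Going by the values given here, the change to compound 4 is broader still, touching the whole group and the chain, so a sizeable fall is expected, though its size is uncertain because only one step of a number 93.6 percentage points lower from compound 1 to compound 2 (beyond the scatter) guides it. Compound 4 is therefore estimated at 30%, between -10% and 65%, meaning an expected step of a number 50.7 percentage points lower from compound 1 to compound 4 (beyond the scatter).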

Compound 4, a percentage reported as inhibition, in the whole organism at one dose (the size of the read-out at that dose, not a potency): 22.2%
For compound 4 the middle estimate is 7.8 percentage points above the measured one, within the range that was stated.
By their numbers in this assay, from the lowest: compound 2; then compounds 3 and 4 (each within the scatter of the next); then compound 1.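

In this assay, the second replacement at this position gives a number 58.5 percentage points lower from compound 1 to compound 4 (beyond the scatter), so a large drop now follows a sulfur-bearing group as well as the propargylamino change. Compound 1 thus remains well above both compounds that differ from it at this position. The whole group changes at once, so this step cannot show which part of it matters, and no measurement here explains the drop. On these data alone, whether a diethylamino group in place of dimethylamino would keep the value of compound 1 remains open.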